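Methyl for bromo in a seven-ring enone series

A few compounds are considered here, and "the series" means these few. Any claim that something is new, unique, unknown or untested is made for them only; others in the source may bear on it.

Measured so far:
compound 1 `O=C1/C(=C/c2ccc(Br)cc2)CCc2ccccc21` — > 500000 nM
compound 2 `Cc1ccc(/C=C2\CCc3ccccc3C2=O)cc1` — > 500000 nM
compound 3 `O=C1CCCCC/C1=C\c1cccc(Br)c1` — 176000 nM

In a functional assay on MOLT-4 cells (Homo sapiens) for inhibition (on this read-out lower numbers stand for stronger inhibition and higher numbers for weaker inhibition), compound 1 reaches only the limit > 500000 nM, not a number. Compound 2 likewise stops at the limit > 500000 nM. Between them lies (methyl in place of bromo on an aromatic carbon), and the step that the two limits leave unreadable from compound 1 to compound 2 cannot be read, as the limit of > 500000 nM in this assay, at which 2 of the 3 values shown sit, shows. Going by the values given here, compound 3 stands apart with the only true number, 176000 nM; how its core differs from that of compound 1 is not broken down here. Compound 4 `Cc1cccc(/C=C2\CCCCCC2=O)c1`, not yet measured, carries methyl in place of bromo on an aromatic carbon. This is the same kind of change as in the measured pair, but the place differs: there it is para to a large group, here meta to a group of 9 heavy atoms. With no readable size from the earlier step, the change is expected to be small, a 1.4-fold higher number from compound 3 to compound 4 (0.15 log units; within the scatter). Compound 4 is therefore estimated at 250000 nM, between 80000 nM and 600000 nM.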

Compound 4, half-maximal inhibitory concentration: 228000 nM
Compound 4: the middle estimate sits 1.1-fold (0.04 log units) above what was measured; measured number inside the range.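

In this assay, methyl in place of bromo gives a 1.3-fold higher number from compound 3 to compound 4 (0.11 log units; within the scatter), so on this core the two groups cannot be told apart. The same swap on the core of compound 1 cannot be read, since the values of compound 1 and compound 2 are both limits and not numbers: the limit of > 500000 nM in this assay, at which 2 of the 4 values shown sit. One readable pair, therefore, does not show that the change carries from one core to another, and the swap also sits at a different place on the ring in each pair.

From the compounds shown here alone, it remains open whether an amine or a carboxylic acid at this place would shift the number beyond the scatter. Going by these compounds, it also remains open whether either core could give a much lower number.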